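Swapping the Aryl Group on a Nicotinamide Diazabicycle

The compounds below may be only part of what the source reports. "The series", "measured", "known", "first", "only" and "open" are said of these compounds alone.

Measured compounds:
- compound 1, `O=C(Nc1ccccc1F)c1cncc(N2CC3CC(C2)N3)c1`: 102 nM
- compound 2, `COc1ccc(NC(=O)c2cncc(N3CC4CC(C3)N4)c2)cc1OC`: 516 nM

Both compounds share a core in which an amide joins a bicyclic amine-bearing pyridine to an aromatic ring, and they differ only in that ring. In an assay on cells for displacement of a labelled ligand from Neuronal acetylcholine receptor; alpha3/beta4 (Homo sapiens) (a higher number here means a weaker inhibitor, a lower number a stronger inhibitor), compound 1 gives 102 nM, and compound 2 gives 516 nM. Compound 1 therefore stands as the stronger of the two, since the gap to compound 2 lies beyond the usual scatter.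

Compound 3, `O=C(Nc1cccc(Cl)c1)c1cncc(N2CC3CC(C2)N3)c1`, has not yet been measured. It is derived from compound 1 by a single exchange: 3-chlorophenyl in place of 2-fluorophenyl on an amide-type nitrogen. Nothing measured here isolates this exact change, so the expected step rests only on the two numbers shown, which tell that altering the aromatic ring can move the inhibition constant by a noticeable amount. The expected step in this assay is a 1.6-fold higher number from compound 1 to compound 3 (0.20 log units; within the scatter), a modest shift toward a weaker inhibitor. The inhibition constant of compound 3 is estimated at 160 nM, with a plausible range from 50 nM to 500 nM.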

Compound 3, inhibition constant: 59 nM
For compound 3 the middle estimate is 2.7-fold (0.43 log units) above the measured one; the measured number falls inside the stated range.
By their numbers in this assay, from the lowest: compounds 3 and 1 (each within the scatter of the next); then compound 2.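

In this assay, 3-chlorophenyl in place of 2-fluorophenyl on the amide-type nitrogen gives a 1.7-fold lower number from compound 1 to compound 3 (0.24 log units; within the scatter) and so leaves no readable difference between the two compounds. This position therefore accepts either of these halogen-bearing rings, even though the halogen and its place on the ring both change in this one swap, while compound 2, with its methoxy-bearing ring, gives 516 nM and remains the compound set apart from the other two. Nothing measured here explains why the two halogen-bearing rings read alike.

Since the halogen and its place change together, this pair cannot say what each change does alone, and a plain phenyl ring with no halogen would be needed to show whether a halogen matters here at all. On these data alone, it also remains open how this position would respond to a ring carrying an amine or a carboxylic acid, groups quite unlike the halogens and methoxy groups seen so far, so the range of rings accepted at this amide-type nitrogen is still undefined.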